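This account rests on a few compounds, and the source may have more. Where it says the series, first, only, none or still open, it means among the compounds named here.

Measured compounds in a functional assay on B16-F10 cells (Mus musculus) for cytotoxicity, read by CCK-8 assay, with a stated time of 48 h; a lower number here means a stronger inhibitor, a higher number a weaker inhibitor:
compound 1 `O=c1oc2ccccc2c(Cl)c1/C=N/c1ccc(S(=O)(=O)Nc2nccs2)cc1`: 300 nM
compound 2 `Cc1cc(NS(=O)(=O)c2ccc(/N=C/c3c(Cl)c4ccccc4oc3=O)cc2)no1`: 270 nM
compound 3 `CC(C)(C)c1cc(C(C)(C)C)c2oc(=O)c(/C=N/c3ccc(S(N)(=O)=O)cc3)c(Cl)c2c1`: 240 nM

Compound 3 gives the lowest number of the three, but its gaps to compound 2 and to compound 1 both lie within the scatter, so no order among the three can be read from these values.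

Compound 4 `Cc1ccnc(NS(=O)(=O)c2ccc(/N=C/c3c(Cl)c4cc(C(C)(C)C)cc(C(C)(C)C)c4oc3=O)cc2)n1` differs from compound 3 by 4-methylpyrimidin-2-yl in place of hydrogen on a sulfonamide nitrogen. For the measured compounds named here, the only measured step touching that position is a 1.1-fold lower number from compound 1 to compound 2 (0.05 log units; within the scatter), a swap of one heteroaryl for another on the same nitrogen. Compounds 1 and 2, which carry a heteroaryl there, sit within the scatter of compound 3, which carries hydrogen there. On this basis no step beyond the scatter is expected in this assay, a 1.0-fold higher number from compound 3 to compound 4 (0.02 log units; within the scatter). Compound 4 is therefore estimated at 250 nM, with a range of 120 nM to 500 nM.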

Compound 4, half-maximal inhibitory concentration: 190 nM
Compound 4: the middle estimate sits 1.3-fold (0.12 log units) above what was measured, and the stated range covers the measured number.
By their numbers in this assay, from the lowest: compounds 4, 3, 2 and 1 (each within the scatter of the next).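

In this assay, for the compounds shown here, 4-methylpyrimidin-2-yl in place of hydrogen on the sulfonamide nitrogen gives a 1.3-fold lower number from compound 3 to compound 4 (0.10 log units; within the scatter) and this is the first comparison of hydrogen with a heteroaryl there on an otherwise unchanged structure. The earlier step at this nitrogen only exchanged one heteroaryl for another, so this nitrogen now carries a six-membered aromatic ring without a step beyond the scatter. No measured evidence explains this result. Open, from the compounds shown here alone, is whether an amine, a carboxylic acid or a longer alkyl chain on this nitrogen would give a step beyond the scatter. Also open, going by these compounds, is whether 4-methylpyrimidin-2-yl behaves alike on the core of compound 1.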